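This account rests on a few compounds, and the source may have more. Where it says the series, first, only, none or still open, it means among the compounds named here.

Measured so far:
- compound 1 `COC(=O)c1ccc(-n2cc(CCCNC(=O)c3ccc(C)cc3)nn2)cc1`: > 100000 nM
- compound 2 `COC(=O)c1ccc(-n2cc(CCCNC(=S)c3ccc(C)cc3)nn2)cc1`: > 100000 nM
- compound 3 `COC(=O)c1ccc(-n2cc(CCCOC(=O)c3ccc(C)cc3)nn2)cc1`: > 100000 nM

In a functional assay on A549 cells (Homo sapiens) for inhibition, read by MTT assay, with a stated time of 72 h (a higher number here means a weaker inhibitor, a lower number a stronger inhibitor), compound 1 gives > 100000 nM, which is a limit of the assay and not a number. The same holds for compound 2 at > 100000 nM. It holds too for compound 3 at > 100000 nM. The whole picture so far is therefore (the limit of > 100000 nM in this assay, at which 3 of the 3 values shown sit).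

The next compound to be tested is compound 4 `COC(=O)c1ccc(-n2cc(CCCNC(=O)Nc3ccc(C)cc3)nn2)cc1`. Its change from compound 1 is (4-methylphenyl)amino in place of 4-methylphenyl on a carbonyl carbon. Put simply, (4-methylphenyl)amino stands in place of 4-methylphenyl on a carbonyl carbon, and the rest of the molecule stays the same.

Only one measured step links two of these compounds: a step that the two limits leave unreadable from compound 1 to compound 2. Its size cannot be read, so it offers no measured size to carry over to compound 4. Compound 3 also differs from compound 1, yet it too yields only a limit. None of the three compounds provides a number to build on, so no step in either direction can be forecast with any confidence in this assay. The most likely outcome is that compound 4 stays at the same limit as the others.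

The step expected is a number no higher from compound 1 to compound 4 (the limit leaves the size open). For compound 4 the estimated value is 100000 nM, with an expected range from 30000 nM to 200000 nM.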

Compound 4, half-maximal inhibitory concentration: 36400 nM
The estimate for compound 4 lay 2.7-fold (0.44 log units) above the measured number; measured number inside the range.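

In this assay, putting (4-methylphenyl)amino, which brings one nitrogen and one hydrogen-bond donor, in place of 4-methylphenyl on a carbonyl carbon gives an at least 2.7-fold lower number from compound 1 to compound 4 (0.43 log units; beyond the scatter). Compound 1 gives > 100000 nM, which is a limit of the assay and not a number, so this step sets only a lower bound on the size of the change, though it does show that this position can respond to a change in the group on the carbonyl carbon. Compound 4 is the only compound here with a true number, which makes it the first reference point for later comparisons, while the others give no number to compare: the limit of > 100000 nM in this assay, at which 3 of the 4 values shown sit.

The step from compound 1 to compound 2 cannot be read, so the effect of replacing the carbonyl oxygen with sulfur remains unknown, and the compounds shown do not reveal whether the nitrogen or its hydrogen accounts for the lower number in compound 4. Going by these compounds, a methylamino link bearing the same 4-methylphenyl ring, or a benzylamino group on the same carbonyl carbon, would be a natural way to probe this, and how either would read remains open.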